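This account rests on a few compounds, and the source may have more. Where it says the series, first, only, none or still open, it means among the compounds named here.

Measured so far in an ADME assay on Huh-7 cells (Homo sapiens) for cytotoxicity, with a stated time of 72 h; on this read-out lower numbers stand for higher toxicity in this test and higher numbers for lower toxicity in this test:
- Compound 1 `CCS(=O)(=O)Nc1ccc2c(c1)S(=O)(=O)N=C(c1c(O)c(-c3cccs3)nn(CCC(C)C)c1=O)N2`: > 33000 nM
- Compound 2 `CC(C)CCn1nc(-c2cccs2)c(O)c(C2=NS(=O)(=O)c3cc(NS(=O)(=O)C4CC4)ccc3N2)c1=O`: > 1000 nM
- Compound 3 `CC(C)CCn1nc(C2CCCCC2)c(O)c(C2=NS(=O)(=O)c3cc(NS(C)(=O)=O)ccc3N2)c1=O`: > 1000 nM

All three entries are limits of the assay and not numbers. Compound 3 gives > 1000 nM, which is such a limit. It shares its place with one other compound, as the limit of > 1000 nM in this assay, at which 2 of the 3 values shown sit, shows, while the remaining compound stands at the limit of > 33000 nM in this assay, at which 1 of the 3 values shown sits. Going by the values given here, no compound in this assay has yet returned an actual number.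

Compound 4 `CC(C)CCn1nc(CC(C)C)c(O)c(C2=NS(=O)(=O)c3cc(NS(C)(=O)=O)ccc3N2)c1=O` differs from compound 3 in one place, with isobutyl in place of cyclohexyl on an aromatic carbon. Among the compounds with values here, the only measured step, a step that the two limits leave unreadable from compound 1 to compound 2, puts cyclopropyl in place of ethyl on a sulfonyl sulfur. That is a different change at a different place, and it gives no size to carry over. With no readable step to draw on, no change beyond the usual scatter is expected, in either direction, and low toxicity in this test is expected to continue. The estimated step that the limit leaves unreadable from compound 3 to compound 4 is therefore only a loose expectation. The estimate for compound 4 is 10000 nM, with an expected range from 1500 nM to 50000 nM.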

Compound 4, half-maximal cytotoxic concentration: > 1000 nM
Compound 4: no number, only a limit; the forecaster's own chance of this, stated with the estimate: 80%; the middle value does not contradict the limit.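

Compound 3 and compound 4 each return only a limit of the assay and not a number in this assay, so the step of isobutyl in place of cyclohexyl cannot be read. The compounds shown leave open at what concentration any of them would reach the half-maximal cytotoxic effect, and whether this change alters it.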